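The source may report more compounds than this note shows. Statements on the series, on what has been measured and on what is new or still open speak of the compounds shown alone.

Of the compounds shown here, three have been measured in a functional assay on 786-0 cells (Homo sapiens) for inhibition, read by sulforhodamine B assay, with a stated time of 48 h; on this read-out higher numbers stand for weaker inhibition of growth and lower numbers for stronger inhibition of growth. Compound 1, `COc1ccc(-c2cc(/C=C/C(=O)c3ccc(N)cc3)[nH]n2)cc1`, gives 5690 nM in this assay. Compound 2, `COc1ccc(-c2cc(/C=C/C(=O)c3ccc(N)cc3)[nH]n2)cc1OC`, gives 4390 nM. Compound 3, `COc1cc(C(=O)/C=C/c2cc(-c3cc(OC)c(OC)c(OC)c3)n[nH]2)cc(OC)c1OC`, gives 3250 nM, and its gaps to compound 2 and to compound 1 both lie within the scatter of this assay. Compound 2 and compound 1 differ in one place, (hydrogen in place of methoxy on an aromatic carbon), and this step gives a 1.3-fold higher number from compound 2 to compound 1 (0.11 log units; within the scatter). How the core of compound 3 differs from that of compound 2 is not broken down here. The compound still to be measured, compound 4, `COc1ccc(-c2cc(/C=C/C(=O)c3cc(OC)c(OC)c(OC)c3)[nH]n2)cc1OC`, stands to compound 3 much as compound 1 stands to compound 2: hydrogen in place of methoxy on an aromatic carbon. The surroundings are not identical, since in compound 3 the aromatic carbon that loses its methoxy is also meta to a methoxy group (2 heavy atoms), so this is the same kind of change rather than the same change. Because the earlier step gave a 1.3-fold higher number from compound 2 to compound 1 (0.11 log units; within the scatter), the step is expected to be a 1.3-fold higher number from compound 3 to compound 4 (0.11 log units; within the scatter). Compound 4 is therefore expected to give about 4200 nM in this assay, most likely between 2000 nM and 9000 nM.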

Compound 4, concentration for total growth inhibition: 2900 nM
For compound 4 the middle estimate is 1.4-fold (0.16 log units) above the measured one, and the stated range covers the measured number.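

In this assay, putting hydrogen in place of methoxy on an aromatic carbon gives a 1.1-fold lower number from compound 3 to compound 4 (0.05 log units; within the scatter). Set beside the earlier step, the result on the second core agrees with that on the first: the same change on two cores in this assay, a 1.3-fold higher number (0.11 log units; within the scatter) from compound 2 to compound 1 and a 1.1-fold lower number (0.05 log units; within the scatter) from compound 3 to compound 4, 1.5-fold (0.16 log units) apart, within the scatter of two such steps. Going by these compounds alone, this shows that on these two cores the exchange of methoxy for hydrogen stays within the scatter, so the small size of the step carries over from one core to the other, but it gives no direction for the step, and two pairs do not show that the same would hold on any other core of the series.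

The compounds shown carry only methoxy or hydrogen at the place that changes, so it remains open whether a hydroxyl group, an ethoxy group or a chlorine atom there would also stay within the scatter. Also open, from the compounds shown here alone, is whether a step of any size appears when more than one methoxy group is replaced at once.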